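The compounds below may be only part of what the source reports. "The series", "measured", "known", "first", "only" and "open" are said of these compounds alone.

Compound 1 `CC(C)C(=O)OC1CCC(CN2CCN(c3cc(=O)c4cc(C(F)(F)F)cc([N+](=O)[O-])c4s3)CC2)CC1`: > 64 ug/mL
Compound 2 `O=C(OC1CCC(CN2CCN(c3cc(=O)c4cc(C(F)(F)F)cc([N+](=O)[O-])c4s3)CC2)CC1)c1cccc(C(F)(F)F)c1`: > 64 ug/mL

In an ADME assay on Vero cells (Chlorocebus sabaeus) for cytotoxicity, read by MTT assay, with a stated time of 48 h (on this read-out lower numbers stand for stronger inhibition and higher numbers for weaker inhibition), compound 1 gives > 64 ug/mL, which is a limit and not a number. Compound 2 gives > 64 ug/mL, also a limit, so its standing is known only as a limit. Both measured compounds sit at one boundary: the limit of > 64 ug/mL in this assay, at which 2 of the 2 values shown sit. For the measured compounds named here, the one measured step, a step that the two limits leave unreadable from compound 1 to compound 2, has no readable size.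

Compound 3 `O=C(OC1CCC(CN2CCN(c3cc(=O)c4cc(C(F)(F)F)cc([N+](=O)[O-])c4s3)CC2)CC1)C1CCC1` carries cyclobutyl in place of 3-(trifluoromethyl)phenyl on a carbonyl carbon, with cyclobutyl in place of 3-(trifluoromethyl)phenyl on a carbonyl carbon. Given a step that the two limits leave unreadable from compound 1 to compound 2, no measurable change is expected, and the expected step is a step that the limit leaves unreadable from compound 2 to compound 3, with no clear direction. Compound 3 is estimated at 80 ug/mL, with an expected range of 45 ug/mL to 150 ug/mL, and will probably be reported only as a limit.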

Compound 3, half-maximal inhibitory concentration: > 64 ug/mL
Compound 3 gave a limit, no number; the forecaster's own chance of this, stated with the estimate: 85%; the middle value does not contradict the limit.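

No new step can be read among compound 1, compound 2 and compound 3, as each value is a limit and not a number: the limit of > 64 ug/mL in this assay, at which 3 of the 3 values shown sit.

The compounds shown leave open how isopropyl, 3-(trifluoromethyl)phenyl and cyclobutyl on a carbonyl carbon compare numerically.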